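The compounds below may be only part of what the source reports. "The series", "measured", "known", "first", "only" and "open" are said of these compounds alone.

Compound 1, `COc1ccc2c(c1)c(-c1cc(C(F)(F)F)c(C#N)c(-c3cn(S(=O)(=O)c4ccc(C)cc4)c4ccc(OC)cc34)n1)cn2S(=O)(=O)c1ccc(C)cc1`: > 100000 nM
Compound 2, `COc1ccc2c(-c3cc(C(F)(F)F)c(C#N)c(-c4cn(S(=O)(=O)c5ccc(C)cc5)c5cc(OC)ccc45)n3)cn(S(=O)(=O)c3ccc(C)cc3)c2c1`: > 100000 nM

In a functional assay on P388 cells (Mus musculus) for cytotoxicity (a higher number here means a weaker inhibitor, a lower number a stronger inhibitor), compound 1 gives > 100000 nM, which is a limit of the assay rather than a measured number. Compound 2 likewise gives > 100000 nM in this assay, again only a limit. Compound 2 therefore stands at the edge of what the assay can report, sharing that position with compound 1: the limit of > 100000 nM in this assay, at which 2 of the 2 values shown sit.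

Compound 3, `COc1ccc2c(-c3cc(C(F)(F)F)cc(-c4cn(S(=O)(=O)c5ccc(C)cc5)c5cc(OC)ccc45)n3)cn(S(=O)(=O)c3ccc(C)cc3)c2c1`, differs from compound 2 by hydrogen in place of cyano on an aromatic carbon, in words: hydrogen in place of cyano on an aromatic carbon. Going by the values given here, no measured pair of compounds shows what this change does to the read-out. With the two known values both at the limit, the expected step is a number no higher from compound 2 to compound 3 (the limit leaves the size open), and compound 3 would most likely again be reported only as a limit. Compound 3 is estimated at 100000 nM, within a range from 30000 nM to 300000 nM.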

Compound 3, half-maximal inhibitory concentration: 4300 nM
Beside the measured number, compound 3's estimate is 23-fold (1.37 log units) above it; the measured number lies below the stated range.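

Replacing the cyano group with hydrogen on the six-membered aromatic ring with 1 nitrogen gives, in this assay, an at least 23-fold lower number from compound 2 to compound 3 (1.36 log units; beyond the scatter). Going by these compounds alone, compound 3 is thus the first compound here with a measured number rather than a limit, which shows that what sits at this position, ortho to a trifluoromethyl group, can decide whether cytotoxicity is seen at all. The step has only a lower bound, as compound 2 is reported only as a limit: the limit of > 100000 nM in this assay, at which 2 of the 3 values shown sit.

As far as these compounds go, whether the change from cyano is what matters, or hydrogen is unusually favourable, stays open, since no other group, such as an amine or a carboxylic acid, appears at this position. From the compounds shown here alone, whether the same replacement would have a similar effect on compound 1 also remains unknown.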